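Ethyl in place of hydrogen on compound 2

The compounds below may be only part of what the source reports. "The series", "measured", "known", "first", "only" and "open" are said of these compounds alone.

Among the measured compounds shown here, in a functional assay on RAW264.7 cells (Mus musculus) for inhibition, read by Griess assay, with stated times of 1 h and 24 h (on this read-out higher numbers stand for weaker inhibition and lower numbers for stronger inhibition), compound 2 (`O=C1CC(c2ccccc2O)Oc2ccccc21`) gives 71300 nM and so holds the higher of the two numbers measured so far. For the measured compounds named here, the only other measured compound, compound 1 (`O=C1CC(c2ccccc2OCc2ccccc2)Oc2ccccc21`), gives 18900 nM and is the nearest to it. The next compound to be measured is compound 3 (`CCOc1ccccc1C1CC(=O)c2ccccc2O1`), which differs from compound 2 by ethyl in place of hydrogen on an oxygen on an aromatic ring, or hydroxy to ethoxy (ethyl in place of hydrogen on an oxygen on an aromatic ring). Going by the values given here, one measured step bears on this change, and it sits on the same oxygen. With hydrogen in place of benzyl, the data show a 3.8-fold higher number from compound 1 to compound 2 (0.58 log units; beyond the scatter) as a modest change beyond the scatter. Read backwards, that step points to a lower number when the hydrogen is replaced. Ethyl is not benzyl, however, so only part of that modest step is expected to return in this assay here. The expected change is a 2.2-fold lower number from compound 2 to compound 3 (0.33 log units; beyond the scatter) and it remains uncertain, since it rests on one step alone. Compound 3 is estimated at 33000 nM with 15000 nM to 75000 nM as the expected range.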

Compound 3, half-maximal inhibitory concentration: 38500 nM
Compound 3: the middle estimate sits 1.2-fold (0.07 log units) below what was measured, within the range that was stated.
By their numbers in this assay, from the lowest: compound 1; then compounds 3 and 2 (each within the scatter of the next).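

On this oxygen, ethyl in place of hydrogen leaves compound 3 and compound 2 unresolved in this assay with a 1.9-fold lower number from compound 2 to compound 3 (0.27 log units; within the scatter) and so gives no order between them. Methyl in place of phenyl on the saturated chain carbon bound to that oxygen gives a 2.0-fold higher number from compound 1 to compound 3 (0.31 log units; beyond the scatter) as a modest change beyond the scatter, so among these three compounds only compound 1, which carries benzyl, stands apart from the other two, and this shows what the earlier step of benzyl against hydrogen alone could not: on this single example, an ethyl group on the oxygen does not reach the number of compound 1. No measurement shown here gives a reason for these differences.

The compounds shown leave open how the number would run along a series on this oxygen, since only hydrogen, ethyl and benzyl appear there. Going by these compounds, whether a longer chain such as butyl, a phenethyl group or a chain ending in an amine or a carboxylic acid would track compound 1 or stay with compound 2 and compound 3 remains unknown.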